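The compounds below may be only part of what the source reports. "The series", "measured", "known", "first", "only" and "open" are said of these compounds alone.

Measured in a functional assay on Hep 3B2 cells (Homo sapiens) for inhibition, read by sulforhodamine B assay, with a stated time of 72 h; on this read-out higher numbers stand for weaker inhibition and lower numbers for stronger inhibition:
- Compound 1 `C[C@H](Nc1ncnc2[nH]cnc12)c1nn(-c2cccnc2)c2cc(Cl)ccc12`: > 40000 nM (a limit)
- Compound 2 `C[C@H](Nc1ncnc2[nH]cnc12)c1nn(-c2cccnc2)c2cc(F)ccc12`: 34500 nM
- Compound 3 `C[C@H](Nc1ncnc2[nH]cnc12)c1nn(-c2ccccn2)c2cc(F)ccc12`: > 40000 nM (a limit)

Within the data shown here, compound 2 gives the only actual number of the three, 34500 nM. The other two values are limits, and the set sits against (the limit of > 40000 nM in this assay, at which 2 of the 3 values shown sit).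

Compound 4 `CC[C@H](Nc1ncnc2[nH]cnc12)c1nn(-c2cccnc2)c2cc(F)ccc12` keeps everything in compound 2 except one place: methyl in place of hydrogen on a saturated chain carbon, two bonds along the chain from an aromatic carbon and a nitrogen on an aromatic ring. In words, methyl stands in place of hydrogen on a saturated chain carbon, so that methyl becomes ethyl.

Among the measured compounds shown here, no measured step touches this chain. The two steps available, an at least 1.1-fold lower number from compound 1 to compound 2 (0.06 log units; that floor lies within the scatter) and an at least 1.1-fold higher number from compound 2 to compound 3 (0.06 log units; that floor lies within the scatter), concern other changes, and each is only a floor. They give no sign of how the chain behaves, so no step beyond the scatter is expected in this assay. The expected change is a 1.0-fold lower number from compound 2 to compound 4 (0.02 log units; within the scatter), and a reading that reports only a limit would be no surprise.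

This expectation rests on compound 2 at 34500 nM. For compound 4 the estimated value is 33000 nM, with an expected range from 16000 nM to 40000 nM.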

Compound 4, half-maximal inhibitory concentration: > 40000 nM
Compound 4 ended at the assay's limit; the forecaster's own chance of this, stated with the estimate: 50%; at least 1.2-fold (0.08 log units) between middle value and limit.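

In this assay compound 4 gives > 40000 nM, which is a limit. Methyl to ethyl on the saturated chain carbon, the first change at this position, gives an at least 1.1-fold higher number from compound 2 to compound 4 (0.06 log units; that floor lies within the scatter), so this change brought no reading of stronger inhibition. The result adds this position to the others at the top of the measurable range: the limit of > 40000 nM in this assay, at which 3 of the 4 values shown sit.

On these data alone, how far compound 4 truly lies from compound 2 stays open, so the data cannot tell whether ethyl weakens inhibition at all or leaves it unchanged. Also open, as far as these compounds go, is whether a propyl chain, an amine or a carboxylic acid on this saturated chain carbon would give a number clearly lower than that of compound 2.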